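The compounds below may be only part of what the source reports. "The series", "measured", "known", "first", "only" and "open" are said of these compounds alone.

Measured compounds:
compound 1, `COc1ccc2c(c1)OC(c1cc(OC)c(OC)c(OC)c1)C(C=O)=C2` — 13500 nM
compound 2, `COc1ccc2c(c1)OC(c1cc(OC)c(OC)c(OC)c1)C(/C=N/O)=C2` — 14100 nM

In a functional assay for inhibition of nuclear factor NF-kappa-B complex (Homo sapiens) (a higher number here means a weaker inhibitor, a lower number a stronger inhibitor), compound 2 gives 14100 nM, and compound 1 gives 13500 nM. The two numbers are separated only by the step of a 1.0-fold higher number from compound 1 to compound 2 (0.02 log units; within the scatter), so on the numbers shown compound 2 stands essentially level with compound 1, neither being distinguishable from the other.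

Compound 3 is `COc1ccc2c(c1)OC(c1cc(OC)c(OC)c(OC)c1)C(C(C)=O)=C2`. Its difference from compound 2 is a group of 3 heavy atoms (2 carbon, 1 oxygen; no ring) in place of a group of 3 heavy atoms (1 carbon, 1 nitrogen, 1 oxygen; no ring), on a double-bonded ring carbon: the group carrying one nitrogen and one oxygen leaves, and acetyl enters, at the same position on the double-bonded ring carbon of the shared core.

Within the data shown here, the only measured step that bears on this position is the one from compound 1 to compound 2, in which a group of two heavy atoms gave way to a group of three heavy atoms on the same ring carbon; that step was a 1.0-fold higher number from compound 1 to compound 2 (0.02 log units; within the scatter), within the scatter. On that basis the exchange leading to compound 3 is expected to give a step of a 1.1-fold lower number from compound 2 to compound 3 (0.04 log units; within the scatter) in this assay, that is, no change beyond the scatter.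

Compound 3 is therefore estimated at 13000 nM in this assay, with a range from 5000 nM to 35000 nM.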

Compound 3, half-maximal inhibitory concentration: 14100 nM
The estimate for compound 3 lay 1.1-fold (0.04 log units) below the measured number; low and high end bracket the measured number.
By their numbers in this assay, from the lowest: compounds 1, 2 and 3 (each within the scatter of the next).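

In this assay the exchange on the double-bonded ring carbon of the group carrying one nitrogen and one oxygen for acetyl gives no change at the digits printed from compound 2 to compound 3 (within the scatter) and thus lies within the scatter, even though the group that leaves has 1 hydrogen-bond donor and acetyl has 0. Methyl in place of hydrogen on the carbonyl carbon gives a 1.0-fold higher number from compound 1 to compound 3 (0.02 log units; within the scatter) and also lies within the scatter, so the three groups now seen at this position cannot be told apart in this assay, and neither the donor nor that methyl shows any measurable effect on the number here. No measurement is at hand that could explain this flat result.

From the compounds shown here alone, whether an amine, a carboxylic acid or a longer chain such as butanoyl on this ring carbon would move the number beyond the scatter remains open. The compounds shown also leave open whether any change at this position, or anywhere else on the shared core, can produce a step larger than the scatter in this assay at all.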